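Series notes: substituent swap on the shared core

This account rests on a few compounds, and the source may have more. Where it says the series, first, only, none or still open, it means among the compounds named here.

Compound 1 `O=C(/C=C/c1ccc2c(c1)B(O)OC2)c1ccc(-c2ccccc2)cc1` is the reference point. Within the data shown here, in a toxicity assay on MCF-10A cells (Homo sapiens) for cytotoxicity, read by MTT assay, with a stated time of 48 h (on this read-out higher numbers stand for weaker inhibition and lower numbers for stronger inhibition), compound 1 gives 20700 nM, the second highest of the three numbers measured so far. Compound 3 `O=C(/C=C/c1ccc2c(c1)B(O)OC2)c1ccc(OCc2ccccc2)cc1` sits nearest, giving 23300 nM in this assay, while compound 2 `O=C(/C=C/c1ccc2c(c1)B(O)OC2)c1ccc(Cl)cc1` sits furthest, giving 12100 nM. The steps of a 1.7-fold lower number from compound 1 to compound 2 (0.23 log units; within the scatter) and a 1.1-fold higher number from compound 1 to compound 3 (0.05 log units; within the scatter) both lie within the scatter, as does a 1.9-fold higher number from compound 2 to compound 3 (0.28 log units; within the scatter). Across these three compounds, therefore, changing the group on that aromatic carbon has not moved the read-out beyond what repeated measurements would show.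

Compound 4 `Nc1ccc(C(=O)/C=C/c2ccc3c(c2)B(O)OC3)cc1` is not yet measured. Relative to compound 1 the change is amino in place of phenyl on an aromatic carbon. All three measured steps bear on this change: each of them swaps the group on the same aromatic carbon of the shared core, and none of them produced a number outside the scatter. Among the measured compounds shown here, nothing in the measured set speaks for a larger step from the amino group, though no amino analogue has been measured. The expected step is a 1.0-fold lower number from compound 1 to compound 4 (0.01 log units; within the scatter), that is, none beyond the scatter. Compound 4 is therefore expected to give 20000 nM in this assay, with a range from 8000 nM to 45000 nM.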

Compound 4, half-maximal inhibitory concentration: 19900 nM
Beside the measured number, compound 4's estimate is 1.0-fold (0.00 log units) above it; the range from low to high includes it.
By their numbers in this assay, from the lowest: compounds 2, 4, 1 and 3 (each within the scatter of the next).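

In this assay, the read-out stays within the scatter even when the group on this aromatic carbon, para to a large group, shrinks from phenyl with its 6 heavy atoms to amino with 1 heavy atom, 1 hydrogen-bond donor and 1 hydrogen-bond acceptor (a 1.0-fold lower number from compound 1 to compound 4 (0.02 log units; within the scatter)). The amino group also stays within the scatter of the other two groups, benzyloxy (a 1.2-fold lower number from compound 3 to compound 4 (0.07 log units; within the scatter)) and chloro (a 1.6-fold higher number from compound 2 to compound 4 (0.22 log units; within the scatter)), so in these four compounds neither the loss of the ring nor the entry of the amino group separates one compound from another on this read-out. No measured evidence bears on why this change leaves the read-out within the scatter.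

The compounds shown leave open whether a carboxylic acid or a longer chain ending in an amine on the same aromatic carbon would give a step beyond the scatter. They also leave open whether a change elsewhere on the shared core would move the number more than these swaps have.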